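A few compounds are considered here, and "the series" means these few. Any claim that something is new, unique, unknown or untested is made for them only; others in the source may bear on it.

Measured compounds:
compound 1 `O=C(O)COCCCC[C@H]1[C@H](F)CC[C@@H]1NS(=O)(=O)c1ccc(F)cc1F` — 1800 nM in a functional assay on a cell-free system (plasma) for inhibition of thromboxane A2 receptor (Homo sapiens), read by turbidimetry; on this read-out lower numbers stand for stronger inhibition and higher numbers for weaker inhibition
compound 2 `O=C(O)COCCCC[C@H]1[C@H](F)CC[C@@H]1NS(=O)(=O)c1ccccc1` — 1700 nM
compound 3 `O=C(O)COCCCCC1=CCC[C@@H]1NS(=O)(=O)c1ccc(F)cc1F` — 1800 nM

Compound 1 and compound 3 share no counted difference; the difference between the two cores is not broken down here. Compound 3 stands level with compound 1 at the digits given, and both sit within the scatter of compound 2.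

The change from compound 1 to compound 2 is phenyl in place of 2,4-difluorophenyl on a sulfonyl sulfur. It gives a 1.1-fold lower number from compound 1 to compound 2 (0.02 log units; within the scatter).

Compound 4 `O=C(O)COCCCCC1=CCC[C@@H]1NS(=O)(=O)c1ccccc1` is not yet measured. It is made from compound 3 by the same change, (phenyl in place of 2,4-difluorophenyl on a sulfonyl sulfur), at a place described in the same words.

Because a 1.1-fold lower number from compound 1 to compound 2 (0.02 log units; within the scatter) lies within the scatter, a step of similar size is expected from compound 3 to compound 4, namely a 1.1-fold lower number from compound 3 to compound 4 (0.02 log units; within the scatter). Compound 4 is therefore estimated at 1700 nM, between 850 nM and 3400 nM.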

Compound 4, half-maximal inhibitory concentration: 2000 nM
Estimate against measurement, compound 4: 1.2-fold (0.07 log units) below; measured number inside the range.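

In this assay, phenyl in place of 2,4-difluorophenyl on a sulfonyl sulfur gives a 1.1-fold higher number from compound 3 to compound 4 (0.05 log units; within the scatter). Set beside the earlier step, the same change shows no readable difference between the two cores: the same change on two cores in this assay, a 1.1-fold lower number (0.02 log units; within the scatter) from compound 1 to compound 2 and a 1.1-fold higher number (0.05 log units; within the scatter) from compound 3 to compound 4, 1.2-fold (0.07 log units) apart, within the scatter of two such steps. Going by these compounds alone, this shows that a step within the scatter on the core of compound 1 stays within the scatter on the core of compound 3, but it covers only this one exchange; with neither step beyond the scatter, it does not show how a change with a readable effect would carry between the cores.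

Still open, going by these compounds, is whether a nitrile or an amine on the phenyl would move the number beyond the scatter on either core. On these data alone, a longer chain carrying the carboxylic acid also remains open.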